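The source may report more compounds than this note shows. Statements on the series, on what has been measured and on what is new or still open speak of the compounds shown alone.

Measured compounds, with the read-out in an ADME assay on L02 cells (Homo sapiens) for cytotoxicity, read by MTT assay, with a stated time of 48 h; on this read-out lower numbers stand for stronger inhibition and higher numbers for weaker inhibition:

compound 1 `COc1cc2ccc(=O)oc2cc1OCCCOc1no[n+]([O-])c1S(=O)(=O)c1ccccc1`: 7820 nM
compound 2 `COc1cc2ccc(=O)oc2cc1OCCCCOc1no[n+]([O-])c1S(=O)(=O)c1ccccc1`: 9330 nM
compound 3 `COc1cc2cc(NC(C)=O)c(=O)oc2cc1OCCCOc1no[n+]([O-])c1S(=O)(=O)c1ccccc1`: 8360 nM

Going by the values given here, the three numbers in this assay lie close together; no pair is separated by more than the usual scatter, so compound 3 cannot be set apart from compound 1 or compound 2. Among the compounds with values here, the one single-point step available, a 1.1-fold higher number from compound 1 to compound 3 (0.03 log units; within the scatter), shows that putting acetamido on the aromatic carbon changed nothing beyond the scatter. Compound 2 differs from compound 1 in the linker, and its number falls in the same narrow band.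

Compound 4 `COc1cc2cc(N)c(=O)oc2cc1OCCCOc1no[n+]([O-])c1S(=O)(=O)c1ccccc1` is reached from compound 3 by hydrogen in place of acetyl on a nitrogen on an aromatic ring, that is acetamido to amino. Within the data shown here, the step that bears on it is the one from compound 1 to compound 3, which was within the scatter, and the series so far gives no hint that this position moves the read-out at all. Compound 4 is therefore expected to show no step beyond the scatter in this assay, a 1.0-fold higher number from compound 3 to compound 4 (0.01 log units; within the scatter). The estimate for compound 4 is 8500 nM, with a range from 4300 nM to 17000 nM.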

Compound 4, half-maximal inhibitory concentration: 9160 nM
The estimate for compound 4 lay 1.1-fold (0.03 log units) below the measured number, and the stated range covers the measured number.
By their numbers in this assay, from the lowest: compounds 1, 3, 4 and 2 (each within the scatter of the next).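

In this assay the free amino compound gives a second reading at this aromatic carbon: hydrogen in place of acetyl on the nitrogen gives a 1.1-fold higher number from compound 3 to compound 4 (0.04 log units; within the scatter) and amino in place of hydrogen on the aromatic carbon gives a 1.2-fold higher number from compound 1 to compound 4 (0.07 log units; within the scatter) as the matching comparison with the unsubstituted compound. Hydrogen, acetamido and amino at this place therefore cannot be told apart in this read-out, whereas the earlier compounds covered only hydrogen and acetamido. No measurement at hand offers an explanation for this flat reading.

On these data alone, whether a carboxylic acid, a dimethylamino group or a longer acyl chain on this nitrogen would stay within the same narrow band remains open. Also open, as far as these compounds go, is whether amino or acetamido at this place would read the same with the linker of compound 2.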